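A few compounds are considered here, and "the series" means these few. Any claim that something is new, unique, unknown or untested is made for them only; others in the source may bear on it.

Compound 1 `CCNC(=O)/C=C/c1c(/C=C/c2ccc(OC)cc2)cc(OC)cc1OC`: 6990 nM; compound 2 `COc1ccc(/C=C/c2cc(OC)cc(OC)c2/C=C/C(=O)N2CCC(Cl)CC2)cc1`: 4690 nM; compound 3 `COc1ccc(/C=C/c2cc(OC)cc(OC)c2/C=C/C(=O)NC(C)C)cc1`: 4020 nM, all in a functional assay on B16-F10 cells (Mus musculus) for inhibition, read by MTT assay, with a stated time of 48 h; a lower number here means a stronger inhibitor, a higher number a weaker inhibitor.

Compound 3 stands at the low end of these three numbers, yet every step among them is within the scatter: a 1.7-fold lower number from compound 1 to compound 3 (0.24 log units; within the scatter) and a 1.2-fold lower number from compound 2 to compound 3 (0.07 log units; within the scatter). Compound 4 `COc1ccc(/C=C/c2cc(OC)cc(OC)c2/C=C/C(=O)N2CCC(c3ccccc3)CC2)cc1` differs from compound 3 in that (4-phenylpiperidin-1-yl in place of isopropylamino on a carbonyl carbon). For the measured compounds named here, the steps that bear on this are the earlier swaps at the same carbonyl carbon, a 1.5-fold lower number from compound 1 to compound 2 (0.17 log units; within the scatter) and a 1.2-fold lower number from compound 2 to compound 3 (0.07 log units; within the scatter), both small. The change to compound 4 is larger in size, but nothing measured here separates a ring amide from a chain amide beyond the scatter, so no step beyond the scatter is expected in this assay. For compound 4 the expected value is 4500 nM, with a range from 1500 nM to 13000 nM. This is expected to amount to a 1.1-fold higher number from compound 3 to compound 4 (0.05 log units; within the scatter).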

Compound 4, half-maximal inhibitory concentration: 9180 nM
Compound 4: middle estimate off by 2.0-fold (0.31 log units), on the low side; measured number inside the range.
By their numbers in this assay, from the lowest: compounds 3, 2, 1 and 4 (each within the scatter of the next, the first and the last beyond it).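

For the compounds shown here, at the carbonyl carbon, 4-phenylpiperidin-1-yl in place of isopropylamino gives the first step beyond the scatter in this assay, toward a weaker inhibitor: a 2.3-fold higher number from compound 3 to compound 4 (0.36 log units; beyond the scatter). Against the other two amides, the same group stays within the scatter: a 2.0-fold higher number from compound 2 to compound 4 (0.29 log units; within the scatter), with phenyl in place of chloro, and a 1.3-fold higher number from compound 1 to compound 4 (0.12 log units; within the scatter), with 4-phenylpiperidin-1-yl in place of ethylamino. Nothing available explains the larger step.

Going by these compounds, whether the ring or the phenyl drives that step remains open. Plain piperidin-1-yl or benzylamino on the same carbonyl carbon would help separate the two.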